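This account rests on a few compounds, and the source may have more. Where it says the series, first, only, none or still open, it means among the compounds named here.

Of the compounds shown here, three sharing one core have been measured in an ADME assay for permeability, using PAMPA, at pH 7.4; on this read-out higher numbers stand for higher permeability and lower numbers for lower permeability. Compound 1 `Cc1ccc(-c2nc3ccccc3s2)cc1NC(=O)c1cc([N+](=O)[O-])c(N2CCCCC2)cc1Cl` gives < 1 10^-6 cm/s in this assay, which is a limit of the measurement rather than a number (the limit of < 1 10^-6 cm/s in this assay, at which 1 of the 3 values shown sits). Compound 2 `O=C(Nc1ccc(F)c(-c2nc3ccccc3s2)c1)c1cc([N+](=O)[O-])ccc1Cl` gives 17 10^-6 cm/s in this assay. Compound 3 `Cc1cc(NC(=O)c2cc([N+](=O)[O-])ccc2Cl)cc(-c2nc3ccccc3o2)c1O` gives 105 10^-6 cm/s in this assay. Compound 4 `COC(=O)C1CCN(c2cc(Cl)c(C(=O)Nc3cc(-c4nc5ccccc5s4)ccc3C)cc2[N+](=O)[O-])CC1` has not been measured yet; it differs from compound 1 by methoxycarbonyl in place of hydrogen on a saturated ring carbon. For the measured compounds named here, no measured pair shows this kind of change, so the step is expected to be small: a number no lower from compound 1 to compound 4 (the limit leaves the size open), staying within the usual scatter, with a fair chance that only a limit is reported again. In this assay compound 4 is expected at 1 10^-6 cm/s, within a range from 0.4 10^-6 cm/s to 4 10^-6 cm/s.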

Compound 4, apparent permeability: 24 10^-6 cm/s
Beside the measured number, compound 4's estimate is 24-fold (1.38 log units) below it; the whole stated range lies below it.
By their numbers in this assay, from the lowest: compounds 2 and 4 (each within the scatter of the next); then compound 3. At a limit, below all of these: compound 1.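

Going from piperidin-1-yl to 4-(methoxycarbonyl)piperidin-1-yl, a change on a saturated ring carbon three ring bonds from the ring nitrogen, gives in this assay an at least 24-fold higher number from compound 1 to compound 4 (1.38 log units; beyond the scatter). For the compounds shown here, this is the first sign that this ring carbon can matter on this read-out, as the earlier compounds offered no comparison in one place. The true size of the step stays unknown, as compound 1 stands at a limit and not at a number: the limit of < 1 10^-6 cm/s in this assay, at which 1 of the 4 values shown sits.

The compounds shown do not tell whether another group on this carbon, such as a carboxylic acid, a primary amide or a plain methyl, would raise the number in the same way. With a single step, they also leave open whether the methoxycarbonyl group would do the same on a different core.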